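Half-life notes on a nitro-containing oxime series

The source may hold more compounds than are shown below. What is called first, only, known or untested is meant among the compounds shown, and "the series" means these compounds.

Measured compounds in an ADME assay for pharmacokinetics; on this read-out lower numbers stand for a shorter-lived compound and higher numbers for a longer-lived compound:
- compound 1 `CC/C(=C\C(=N\O)C(N)=O)C(C(C)C)[N+](=O)[O-]` gives 11.5 h
- compound 2 `CC/C(=C\C(=N\O)C(N)=O)C([N+](=O)[O-])C(C)(C)C` gives 48.3 h
- compound 3 `CC/C(=C\C(CNC(=O)c1cccnc1)=N\O)C(C)[N+](=O)[O-]` gives 1.78 h

Compound 1 and compound 2 differ in one place: methyl in place of hydrogen on a saturated chain carbon bound to three saturated chain carbons. This step gave a 4.2-fold higher number from compound 1 to compound 2 (0.62 log units; beyond the scatter).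

Compound 3 carries a different core; how the core of compound 3 differs from the core of compound 1 is not broken down here. In this assay compound 3 sits lowest of the three numbers, and its gaps to compound 1 and to compound 2 both lie beyond the scatter.

Compound 4 `CC(C)/C(=C\C(CNC(=O)c1cccnc1)=N\O)C(C)[N+](=O)[O-]` is not yet measured. It differs from compound 3 by methyl in place of hydrogen on a saturated chain carbon bound to a double-bonded chain carbon and a saturated chain carbon. Going by the values given here, this is the same kind of change as the one from compound 1 to compound 2, but not the same: there the methyl entered on a saturated chain carbon bound to three saturated chain carbons, whereas here it enters on a saturated chain carbon bound to a double-bonded chain carbon and a saturated chain carbon, and it is made on a different core.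

The expectation for compound 4 rests on one precedent only. Because the step of a 4.2-fold higher number from compound 1 to compound 2 (0.62 log units; beyond the scatter) ran upward, compound 4 is expected to read higher than compound 3, but with the place and the core both changed the size is uncertain and the expected step is kept smaller: a 2.5-fold higher number from compound 3 to compound 4 (0.40 log units; beyond the scatter). Compound 4 is thus estimated at 4.5 h, with a range from 2 h to 10 h.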

Compound 4, half-life: 9.67 h
For compound 4 the middle estimate is 2.1-fold (0.33 log units) below the measured one; the measured number falls inside the stated range.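

In this assay the added methyl gives a 5.4-fold higher number from compound 3 to compound 4 (0.74 log units; beyond the scatter), which runs in the same direction as the step on the core of compound 1, and the two steps agree in size: the same change on two cores in this assay, a 4.2-fold higher number (0.62 log units; beyond the scatter) from compound 1 to compound 2 and a 5.4-fold higher number (0.74 log units; beyond the scatter) from compound 3 to compound 4, 1.3-fold (0.11 log units) apart, within the scatter of two such steps. Across these two cores, the change therefore carried over in both direction and size, even though the place also differs: a saturated chain carbon bound to three saturated chain carbons in the first case, and a saturated chain carbon bound to a double-bonded chain carbon and a saturated chain carbon in the second. This agreement rests on a single pair of steps and does not show that the change would hold on any further core, nor can it separate the part played by the place from the part played by the core, and it gives no reason for the rise in half-life.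

The compounds shown leave open whether a longer chain in place of the added methyl would continue the upward run or end it. They also leave open how the half-life would respond if a nitrile or a carboxylic acid stood in place of the nitro group on either core.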